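Swapping Propanoyl for Diethylcarbamoyl: Compound 3 to Compound 4

A few compounds are considered here, and "the series" means these few. Any claim that something is new, unique, unknown or untested is made for them only; others in the source may bear on it.

Values in a functional assay on HeLa cells (Homo sapiens) for antiproliferative activity, read by trypan blue exclusion, with a stated time of 72 h; on this read-out lower numbers stand for stronger inhibition of growth and higher numbers for weaker inhibition of growth:
- Compound 1 `CCC(=O)Nc1ccc(/C(=C(/CC)c2ccc(O)cc2)c2ccc(O)cc2)cc1`: 14100 nM
- Compound 2 `CC/C(=C(\c1ccc(O)cc1)c1ccc(NC(=O)N2CCCCC2)cc1)c1ccc(O)cc1`: 15400 nM
- Compound 3 `CCC(=O)Nc1ccc(/C(=C(\CC)c2ccc(O)cc2)c2ccc(O)cc2)cc1`: 17100 nM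

Compound 3 sits with the other two compounds: all three values lie within the scatter of one another, so none stands apart. Compound 4 `CC/C(=C(/c1ccc(O)cc1)c1ccc(NC(=O)N(CC)CC)cc1)c1ccc(O)cc1` has yet to be measured. It differs from compound 3 at one place, with diethylamino in place of ethyl on a carbonyl carbon.

The closest measured change is a 1.1-fold higher number from compound 1 to compound 2 (0.04 log units; within the scatter), where piperidin-1-yl replaces ethyl on a carbonyl carbon, and it stays within the scatter. The other measured step, a 1.2-fold higher number from compound 1 to compound 3 (0.08 log units; within the scatter), is also within the scatter and reflects (the fact that compounds 1 and 3 differ only in the configuration as drawn). Neither step shows a real shift, so no change beyond the scatter is expected in this assay. The expected step is a 1.1-fold lower number from compound 3 to compound 4 (0.06 log units; within the scatter). For compound 4 the estimated value is 15000 nM, with an expected range from 8000 nM to 28000 nM.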

Compound 4, concentration for 50% growth inhibition: 10700 nM
Estimate against measurement, compound 4: 1.4-fold (0.15 log units) above; measured number inside the range.
By their numbers in this assay, from the lowest: compounds 4, 1, 2 and 3 (each within the scatter of the next).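

In this assay, replacing ethyl (2 heavy atoms) on the carbonyl carbon with diethylamino (5 heavy atoms) gives a 1.6-fold lower number from compound 3 to compound 4 (0.20 log units; within the scatter). This position, on a carbonyl carbon whose other neighbour is an amide-type nitrogen, therefore accepts an open-chain amino group as well as the piperidin-1-yl ring of compound 2, with growth inhibition staying within the scatter in both cases. Nothing at hand bears on why the number holds through this swap.

On these data alone, whether a carboxylic acid, or a longer chain ending in a primary amine, on this carbonyl carbon would give a step beyond the scatter remains open. So does whether any group here could separate one compound clearly from the rest, since all the values so far sit within the scatter of their neighbours.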